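Bringing the Arylamino Link Back in Compound 3

The source may report more compounds than this note shows. Statements on the series, on what has been measured and on what is new or still open speak of the compounds shown alone.

For the measured compounds named here, in a functional assay on HCT-116 cells (Homo sapiens) for inhibition, read by MTT assay, with a stated time of 2 days, tested at 10 uM (on this read-out higher numbers stand for more inhibition of growth at the one concentration tested and lower numbers for less inhibition of growth), compound 2 `CNC(=O)c1cc(Oc2ccc3nc(NC(=O)c4cc(Cl)cc(Cl)c4)sc3c2)ccn1` gives 13.4%, the lower of the two numbers measured so far, whereas compound 1 `CNC(=O)c1cc(Oc2ccc3nc(NC(=O)Nc4ccc(Cl)cc4)sc3c2)ccn1` gives 57.4%. Compound 3 `CNC(=O)c1cc(Oc2ccc3nc(NC(=O)Nc4ccc(Cl)cc4Cl)sc3c2)ccn1` differs from compound 2 by (2,4-dichlorophenyl)amino in place of 3,5-dichlorophenyl on a carbonyl carbon. Going by the values given here, the one measured step that bears on this change, a number 44 percentage points lower from compound 1 to compound 2 (beyond the scatter), was a large loss when an arylamino group on the carbonyl carbon was exchanged for an aryl group; compound 3 reverses that exchange, so a rise of roughly the same size is expected, a number 36.6 percentage points higher from compound 2 to compound 3 (beyond the scatter). Compound 3 is therefore estimated at 50%, within 28% to 72%.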

Compound 3, percent growth inhibition at one concentration: 32.2%
Compound 3: middle estimate off by 17.8 percentage points, on the high side; the measured number falls inside the stated range.
By their numbers in this assay, from the lowest: compound 2; then compound 3; then compound 1.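

In this assay, the arylamino link on the carbonyl carbon recovers only part of the earlier loss (a number 18.8 percentage points higher from compound 2 to compound 3 (beyond the scatter)), so the link alone does not settle the number. The chlorine count on the aryl group also matters, since chloro in place of hydrogen on an aromatic carbon costs activity (a number 25.2 percentage points lower from compound 1 to compound 3 (beyond the scatter)). Nothing available gives a reason for either step. Open, from the compounds shown here alone, is whether fluoro or methoxy in place of that added chloro would keep the number of compound 1.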